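Replacing a long side chain in a well-tolerated series

The source may hold more compounds than are shown below. What is called first, only, known or untested is meant among the compounds shown, and "the series" means these compounds.

Three compounds with one shared core and different groups on an aromatic nitrogen have been measured. In an ADME assay on MT4 cells (Homo sapiens) for inhibition (a higher number here means that more compound is tolerated, a lower number that less compound is tolerated), compound 1 `Cc1cn([C@@H]2O[C@H](CO[Si](C)(C)C(C)(C)C)[C@@]3(OS(=O)(=O)C=C3N)[C@H]2O[Si](C)(C)C(C)(C)C)c(=O)n(CCCN(CC(=O)O)CC(=O)O)c1=O` gives 123000 nM. Compound 2 `Cc1cn([C@@H]2O[C@H](CO[Si](C)(C)C(C)(C)C)[C@@]3(OS(=O)(=O)C=C3N)[C@H]2O[Si](C)(C)C(C)(C)C)c(=O)n(CC(=O)O)c1=O` gives > 155000 nM, which is a limit of the assay and not a number. Compound 3 `CNC(=O)CCCCn1c(=O)c(C)cn([C@@H]2O[C@H](CO[Si](C)(C)C(C)(C)C)[C@@]3(OS(=O)(=O)C=C3N)[C@H]2O[Si](C)(C)C(C)(C)C)c1=O` gives > 250000 nM, which is also a limit. Where compound 3 truly stands in this assay is therefore not known.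

Compound 4 `Cc1cn([C@@H]2O[C@H](CO[Si](C)(C)C(C)(C)C)[C@@]3(OS(=O)(=O)C=C3N)[C@H]2O[Si](C)(C)C(C)(C)C)c(=O)n(/C=C/CO)c1=O` has 3-hydroxyprop-1-en-1-yl in place of 4-(methylcarbamoyl)butyl on an aromatic nitrogen. This exact swap has not been measured, but three measured steps change the same group. The first is an at least 1.2-fold higher number from compound 1 to compound 2 (0.10 log units; that floor lies within the scatter), and the second is an at least 2.0-fold higher number from compound 1 to compound 3 (0.30 log units; that floor lies within the scatter). Neither floor shows a change beyond the scatter. The third, a step that the two limits leave unreadable from compound 2 to compound 3, cannot be sized at all.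

These steps give no firm direction for the new swap, so no step beyond the scatter is expected. The expected step is an at least 1.2-fold lower number from compound 3 to compound 4 (0.09 log units; that floor lies within the scatter). For compound 4 the estimated value in this assay is 200000 nM, with an expected range from 100000 nM to 400000 nM.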

Compound 4, half-maximal cytotoxic concentration: 4000 nM
The estimate for compound 4 lay 50-fold (1.70 log units) above the measured number; measured number below the stated range.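

In this assay, among these compounds, the earlier groups on this aromatic nitrogen showed no step that could be read as beyond the scatter, but 3-hydroxyprop-1-en-1-yl shows that the position is not indifferent to its group: in place of 4-(methylcarbamoyl)butyl it gives an at least 62-fold lower number from compound 3 to compound 4 (1.79 log units; beyond the scatter), in place of carboxymethyl it gives an at least 38-fold lower number from compound 2 to compound 4 (1.58 log units; beyond the scatter), and in place of 3-(bis(carboxymethyl)amino)propyl it gives a 31-fold lower number from compound 1 to compound 4 (1.49 log units; beyond the scatter). Compound 3 stands at a limit of the assay and not at a number, so the step from it is only a floor: the limit of > 250000 nM in this assay, at which 1 of the 4 values shown sits. Compound 2 also stands at a limit of the assay, so the step from it is a floor as well: the limit of > 155000 nM in this assay, at which 1 of the 4 values shown sits.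

Compound 4 changes the length of the chain and its end group together, so the compounds shown cannot tell which of these changes goes with the lower number. A saturated 3-hydroxypropyl chain, or a longer chain ending in a hydroxyl group, would help to separate these changes.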